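The compounds below may be only part of what the source reports. "The series", "measured", "known", "first", "only" and "open" are said of these compounds alone.

Compound 1 `O=C(CCC(=O)c1ccccc1)Nc1nc2ccc(Cl)cc2s1`, compound 2 `Cc1ccc2nc(NC(=O)CCC(=O)c3ccccc3)sc2c1` and compound 3 `O=C(Nc1nc2ccc(Cl)cc2s1)c1ccccc1C(=O)c1ccccc1` share a core that, in a functional assay on the whole organism with Mus musculus as the target, with a stated time of 4 h (a lower number here means that less compound is needed, a higher number that more compound is needed for the effect), gives the same reading for each: compound 1 gives 300 mg/kg, compound 2 gives 300 mg/kg and compound 3 gives 300 mg/kg. Within the data shown here, the one step measured, methyl in place of chloro on an aromatic carbon, shows no change at the digits printed from compound 1 to compound 2 (within the scatter). Compound 3 thus stands level with both companions. Compound 4 `O=C(Nc1nc2ccc(F)cc2s1)c1ccccc1C(=O)c1ccccc1` differs from compound 3 in one place: fluoro in place of chloro on an aromatic carbon. Among the measured compounds shown here, that is again a swap of one small group on the same aromatic carbon, and the only comparable step produced no shift, so no change beyond the scatter is expected in this assay, an estimated no change at the digits printed from compound 3 to compound 4 (within the scatter). Compound 4 is therefore expected to give about 300 mg/kg, within 150 mg/kg to 600 mg/kg.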

Compound 4, minimum effective dose: 300 mg/kg
Compound 4: middle estimate and measured number agree at the digits printed; measured number inside the range.
By their numbers in this assay, from the lowest: compounds 1, 2, 3 and 4 (each within the scatter of the next).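

In this assay, fluoro in place of chloro on this aromatic carbon gives no change at the digits printed from compound 3 to compound 4 (within the scatter). The earlier step, methyl in place of chloro, belonged to the compound 1 pair, so a swap of one small group at this place has now left the reading flat with the rest of compound 3 as well. No measured information here accounts for this flat reading. Going by these compounds, whether an amine, a carboxylic acid or a longer chain on this carbon would move the reading stays open. On these data alone, with all four compounds level, what in these structures can shift it also remains unknown.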